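A few compounds are considered here, and "the series" means these few. Any claim that something is new, unique, unknown or untested is made for them only; others in the source may bear on it.

Of the compounds shown here, three that share one core have been tested in an assay on isolated protein for inhibition of glutathione S-transferase P (Homo sapiens), with a stated time of 10 min; a lower number here means a stronger inhibitor, a higher number a weaker inhibitor. Compound 1 `O=C(CCC(=O)OCCCCCCSc1ccc([N+](=O)[O-])c2nonc12)Nc1ccccc1` gives 10200 nM in this assay. Compound 2 `Cc1ccccc1NC(=O)CCC(=O)OCCCCCCSc1ccc([N+](=O)[O-])c2nonc12` gives 4100 nM. Compound 3 `Cc1ccc(NC(=O)CCC(=O)OCCCCCCSc2ccc([N+](=O)[O-])c3nonc23)cc1` gives 6800 nM, the second highest of the three numbers, with compound 1 nearest and compound 2 furthest, both within the usual scatter of this assay. The change from compound 1 to compound 3 was a 1.5-fold lower number from compound 1 to compound 3 (0.18 log units; within the scatter), from compound 1 to compound 2 it was a 2.5-fold lower number from compound 1 to compound 2 (0.40 log units; beyond the scatter), and from compound 2 to compound 3 it was a 1.7-fold higher number from compound 2 to compound 3 (0.22 log units; within the scatter).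

Compound 4 `COc1ccc(NC(=O)CCC(=O)OCCCCCCSc2ccc([N+](=O)[O-])c3nonc23)cc1` is compound 3 with one change: methoxy in place of methyl on an aromatic carbon. Among the compounds with values here, no measured step here tests a methoxy group, and the two methyl additions gave only small changes, so little beyond the scatter is expected in this assay. The estimate for compound 4 is 6500 nM, between 3000 nM and 14000 nM, which would be a step of a 1.0-fold lower number from compound 3 to compound 4 (0.02 log units; within the scatter) from compound 3.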

Compound 4, half-maximal inhibitory concentration: 420 nM
Compound 4: middle estimate off by 15-fold (1.19 log units), on the high side, outside the stated range (below it).
By their numbers in this assay, from the lowest: compound 4; then compounds 2, 3 and 1 (each within the scatter of the next, the first and the last beyond it).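

In this assay, the group on this aromatic carbon, para to a large group, can matter far more than the methyl compounds suggested: replacing methyl with methoxy gives a 16-fold lower number from compound 3 to compound 4 (1.21 log units; beyond the scatter) for a swap that adds just one oxygen atom. Methoxy in place of hydrogen gives a 24-fold lower number from compound 1 to compound 4 (1.39 log units; beyond the scatter) while the methyl-for-hydrogen step at this place stayed within the scatter, so the identity of the group counts here and not simply the presence of one. The step to the compound with its methyl on the other ring position is also beyond the scatter, at a 9.8-fold lower number from compound 2 to compound 4 (0.99 log units; beyond the scatter) and nothing available explains why methoxy has this effect.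

On these data alone, whether the oxygen atom is what matters stays open, and a hydroxy, an ethoxy or a dimethylamino group at this place would help to separate the possibilities. As far as these compounds go, it is also open whether methoxy would have the same effect elsewhere on the ring or with a shorter or longer chain.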